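The source may hold more compounds than are shown below. What is called first, only, known or untested is meant among the compounds shown, and "the series" means these compounds.

Measured so far in an assay on isolated protein (Mus musculus) for inhibition of IL15-IL15 receptor (Homo sapiens), read by resazurin assay, with stated times of 30 min and 2.5 days; on this read-out lower numbers stand for stronger inhibition and higher numbers for weaker inhibition:
Compound 1 `Cn1c(Cc2nn(C)c(=O)c3ccccc23)nnc1SCCCCCCCC(=O)Nc1ccc(I)cc1` gives 1300 nM.
Compound 2 `CN(C(=O)CCCCCCCSc1nnc(Cc2nn(C)c(=O)c3ccccc23)n1C)c1ccc(Cl)cc1Cl` gives 11900 nM.
Compound 3 `Cn1c(Cc2nn(C)c(=O)c3ccccc23)nnc1SCCCCCCCC(=O)Nc1ccc(Cl)cc1` gives 800 nM.

Compound 3 stands at the low end of these three numbers; its gap to compound 1 is within the scatter, while compound 2 is set apart by a 15-fold lower number from compound 2 to compound 3 (1.17 log units; beyond the scatter). Compound 4 `Cn1c(Cc2nn(C)c(=O)c3ccccc23)nnc1SCCCCCCCC(=O)Nc1ccc(F)cc1F` differs from compound 3 in one place: 2,4-difluorophenyl in place of 4-chlorophenyl on an amide-type nitrogen. Within the data shown here, two measured steps bear on this change. The first, a 1.6-fold lower number from compound 1 to compound 3 (0.21 log units; within the scatter), shows that exchanging one halogen for another stayed within the scatter. The second, a 15-fold lower number from compound 2 to compound 3 (1.17 log units; beyond the scatter), was large, but it altered the halogen pattern and removed the methyl on the amide-type nitrogen in one move. The data do not show what part of that step goes with the ring and what part with the methyl. Compound 4 keeps the amide hydrogen, so only a modest rise in the number is expected, a 1.9-fold higher number from compound 3 to compound 4 (0.27 log units; within the scatter). The estimate for compound 4 is 1500 nM, with a range from 500 nM to 5000 nM.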

Compound 4, half-maximal inhibitory concentration: 2300 nM
Estimate against measurement, compound 4: 1.5-fold (0.19 log units) below; the range from low to high includes it.
By their numbers in this assay, from the lowest: compounds 3, 1 and 4 (each within the scatter of the next, the first and the last beyond it); then compound 2.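

With the amide hydrogen kept, changing only the ring gives a 2.9-fold higher number from compound 3 to compound 4 (0.46 log units; beyond the scatter), so this position responds to more than an exchange of one halogen for another, although a 1.8-fold higher number from compound 1 to compound 4 (0.25 log units; within the scatter) leaves 2,4-difluorophenyl and 4-iodophenyl indistinguishable. The step of a 5.2-fold lower number from compound 2 to compound 4 (0.71 log units; beyond the scatter) again changes the halogens and the methyl together, so it does not separate the two. Nothing available here explains these steps. Still open, as far as these compounds go, is what 4-fluorophenyl or plain phenyl would give on this amide-type nitrogen. Also open, from the compounds shown here alone, is what the methyl alone would do on the amide of compound 3.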